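Trading a diaryl ether for a biaryl on the shared core

This account rests on a few compounds, and the source may have more. Where it says the series, first, only, none or still open, it means among the compounds named here.

Of the compounds shown here, three built on a shared core have been measured in an assay on isolated protein for agonist activity at Bile acid receptor (Homo sapiens), read by AlphaScreen, with a stated time of 30 min; a higher number here means a larger maximal response, a lower number a smaller maximal response. Compound 2 `COc1ccc(Oc2ccc([C@H]3S[C@@H](C)C(=O)Nc4c3c(C)nn4-c3ccccc3C)cc2)cc1` gives 70%, the second highest of the three numbers. Compound 3 `Cc1nn(-c2ccccc2F)c2c1C(c1ccc(Oc3ccccc3)cc1)SC(C)C(=O)N2` gives 72%, which lies within the scatter of compound 2. Compound 1 `COc1ccccc1-n1nc(C)c2c1NC(=O)[C@H](C)S[C@@H]2c1ccc(Oc2ccccc2)cc1` gives 37%, well below compound 2 and beyond the scatter. Compound 4 `COc1ccccc1-c1ccc([C@H]2S[C@@H](C)C(=O)Nc3c2c(C)nn3-c2ccccc2C)cc1` is not yet measured. It differs from compound 2 by 2-methoxyphenyl in place of 4-methoxyphenoxy on an aromatic carbon, placed para to a large group. For the measured compounds named here, no step between measured compounds that differ in one place is known, so the size of this step is uncertain; a modest drop in this assay is expected, perhaps not beyond the scatter. Compound 4 is expected to give 55% (range 30% to 80%), an estimated step of a number 15 percentage points lower from compound 2 to compound 4 (beyond the scatter).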

Compound 4, largest response reached (reported as efficacy), in percent of the reference or control that the assay uses: 50%
Estimate against measurement, compound 4: 5 percentage points above, and the stated range covers the measured number.
By their numbers in this assay, from the lowest: compound 1; then compound 4; then compounds 2 and 3 (each within the scatter of the next).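

For the compounds shown here, this is the first step at this position that can be read on its own: in this assay, 2-methoxyphenyl in place of 4-methoxyphenoxy gives a number 20 percentage points lower from compound 2 to compound 4 (beyond the scatter), so the maximal response depends on the group on this aromatic carbon. The change alters the group's oxygen count and hydrogen-bond acceptors as well as its shape, and this single step cannot separate these differences. From the compounds shown here alone, whether 4-methoxyphenyl or an unsubstituted phenyl on this carbon would restore the response remains open. Nothing at hand accounts for the size of this step.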